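A Trifluoro Hydroxy Chain on a Limit-Bound Amide

A few compounds are considered here, and "the series" means these few. Any claim that something is new, unique, unknown or untested is made for them only; others in the source may bear on it.

In a physicochemical assay for solubility, at pH 6.8 (a lower number here means a less soluble compound, a higher number a more soluble compound), compound 1 `CCN(CC)C1CCN(Cc2ccc(-c3cnc(N)c(C(=O)N[C@H]4CC[C@H](O)CC4)n3)cc2)CC1` reads > 1000000 nM and this is a limit of the assay, not a number. Compound 2 `CCNC(=O)c1nc(-c2ccc(CN(C)C)cc2)cnc1N` gives > 1000000 nM and that too is only a limit. Compound 3 `CN(C)Cc1ccc(-c2cnc(N)c(C(=O)NCC(O)C(F)(F)F)n2)cc1` carries 2,2,2-trifluoro-1-hydroxyethyl in place of methyl on a saturated chain carbon bound to an amide-type nitrogen of compound 2 (2,2,2-trifluoro-1-hydroxyethyl in place of methyl on a saturated chain carbon bound to an amide-type nitrogen). Among the measured compounds shown here, the measured compounds offer no step to go by, only the limit of > 1000000 nM in this assay, at which 2 of the 2 values shown sit, and nothing more. With compound 2 at > 1000000 nM as the sole starting point, no change beyond the usual scatter is expected in either direction. The expected step is a number no higher from compound 2 to compound 3 (the limit leaves the size open) as an estimate only. For compound 3 the estimate in this assay is 1000000 nM (expected range 400000 nM to 2500000 nM) and the assay may well report only a limit again.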

Compound 3, solubility: 880000 nM
Compound 3: the middle estimate sits 1.1-fold (0.06 log units) above what was measured; the range from low to high includes it.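

Among the compounds shown here, compound 3, at 880000 nM in this assay, gives the first reading here that is a number and not a limit, so the change to 2,2,2-trifluoro-1-hydroxyethyl on a saturated chain carbon bound to an amide-type nitrogen can at last be given a step, which reads an at least 1.1-fold lower number from compound 2 to compound 3 (0.05 log units; that floor lies within the scatter) and nothing firmer. Compound 2 stands at > 1000000 nM, and that is a limit of the assay. As far as these compounds go, the true size of the step therefore stays open, and the data offer only this to weigh it by: the limit of > 1000000 nM in this assay, at which 2 of the 3 values shown sit.

From the compounds shown here alone, it remains open whether a plain 2-hydroxyethyl chain without the fluorines would read the same at this place. Nor do the compounds shown tell how an amine or a carboxylic acid on the chain would read.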